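A few compounds are considered here, and "the series" means these few. Any claim that something is new, unique, unknown or untested is made for them only; others in the source may bear on it.

Working notes on the series in a functional assay (strain AB) with Danio rerio as the target, read by microscopy, with a stated time of 1 h; a higher number here means that more compound is needed for the effect, a lower number that less compound is needed.

Compound 1 `CCN1CCc2c(sc(N)c2C(N)=O)C1` gives only a limit, > 25000 nM, in this assay. Compound 2 `CCN1CCc2c(sc(NC(=O)Nc3ccc(Cl)cc3)c2C(=O)NC)C1` likewise gives only a limit, > 25000 nM, in this assay. Going by the values given here, compound 3 `NC(=O)c1c(NC(=O)Nc2ccc(Cl)cc2)sc2c1CCN(CCCNC(=O)CCc1cccnc1)C2` gives 470 nM in this assay, the single numerical reading among the three, the other two sitting at the limit of > 25000 nM in this assay, at which 2 of the 3 values shown sit. Among the compounds with values here, the pair compound 1 and compound 2 differ from compound 3 in more than one place, so no single step between measured compounds is available, and what separates a number from a limit in this set cannot be assigned to one change.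

Compound 4 `CC(C)(C)OC(=O)CCN1CCc2c(sc(NC(=O)Nc3ccc(Cl)cc3)c2C(N)=O)C1` is the next member, not yet measured. It differs from compound 3 by tert-butoxycarbonyl in place of (((2-(pyridin-3-yl)ethyl)carbonyl)amino)methyl on a saturated chain carbon, two bonds along the chain from an amine nitrogen in a ring. The urea and the primary amide of compound 3 are kept, the chain on the ring amine nitrogen is shortened and its end is changed. Within the data shown here, with no measured step on this position, the size of the effect in this assay cannot be read from the set; a loss of some size is the expectation rather than a gain, since both compounds that carry a short substituent on that nitrogen sit at a limit, though neither shares the rest of compound 3. Compound 4 is therefore estimated at 3000 nM, within 600 nM to 25000 nM, which would mean an expected step of a 6.4-fold higher number from compound 3 to compound 4 (0.81 log units; beyond the scatter).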

Compound 4, half-maximal effective concentration: 1100 nM
Estimate against measurement, compound 4: 2.7-fold (0.44 log units) above; the range from low to high includes it.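

This position now has a measured step in this assay: a 2.3-fold higher number from compound 3 to compound 4 (0.37 log units; beyond the scatter). The change removes the six-membered aromatic ring and the hydrogen-bond donor of the (((2-(pyridin-3-yl)ethyl)carbonyl)amino)methyl group, and 12 heavy atoms give way to 7, yet compound 4 still gives a numerical reading, so neither the ring nor the donor is required for a number here. Compound 1 and compound 2 remain limits of the assay, not numbers, and each differs from compound 4 in more than one place: the limit of > 25000 nM in this assay, at which 2 of the 4 values shown sit.

Going by these compounds alone, the single step does not show how much of the change belongs to the lost ring, the lost donor or the shorter chain. It also leaves open how a carboxylic acid, a primary amine or a longer alkyl chain at this position would read.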